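The source may report more compounds than this note shows. Statements on the series, on what has been measured and on what is new or still open speak of the compounds shown alone.

Measured so far:
Compound 1, `Cc1cc(/C=C2\SC(=S)N(Cc3ccc(C(=O)O)cc3)C2=O)c(C)n1-c1ccc(O)c(C(=O)O)c1`, with 105000 nM in an ADME assay on MT2 cells (Homo sapiens) for cytotoxicity, read by XTT assay, with a stated time of 4 days; on this read-out lower numbers stand for higher toxicity in this test and higher numbers for lower toxicity in this test.
Compound 2, `Cc1cc(/C=C2\SC(=S)N(Cc3cccc(C(F)(F)F)c3)C2=O)c(C)n1-c1ccc(O)c(C(=O)O)c1`, with 26300 nM in this assay.

Compound 2 holds the lowest of the two numbers in this assay; the step of a 4.0-fold lower number from compound 1 to compound 2 (0.60 log units; beyond the scatter) separates it from compound 1. Compound 3, `COc1cccc(CN2C(=O)/C(=C/c3cc(C)n(-c4ccc(O)c(C(=O)O)c4)c3C)SC2=S)c1`, has not been measured. Its change from compound 2 is methoxy in place of trifluoromethyl on an aromatic carbon. For the measured compounds named here, the only measured step, a 4.0-fold lower number from compound 1 to compound 2 (0.60 log units; beyond the scatter), touches the same place but swaps in a different group, so it bears on this change only loosely; compound 3 is expected to land between the two measured numbers, a step of a 1.7-fold higher number from compound 2 to compound 3 (0.23 log units; within the scatter). Compound 3 is thus estimated at 45000 nM, within 15000 nM to 130000 nM.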

Compound 3, half-maximal cytotoxic concentration: 102000 nM
For compound 3 the middle estimate is 2.3-fold (0.36 log units) below the measured one, within the range that was stated.
By their numbers in this assay, from the lowest: compound 2; then compounds 3 and 1 (each within the scatter of the next).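

In this assay the outcome depends on the group on this aromatic carbon and not merely on having a substituted aromatic ring there: methoxy in place of trifluoromethyl gives a 3.9-fold higher number from compound 2 to compound 3 (0.59 log units; beyond the scatter) in this series. The other comparison, a 1.0-fold lower number from compound 1 to compound 3 (0.01 log units; within the scatter), shows no separation between the 3-methoxyphenyl and 4-carboxyphenyl groups, leaving compound 2 alone apart from the other two. No available measurement accounts for this difference. From the compounds shown here alone, whether an amine or a longer ether chain on this aromatic carbon would fall with compound 2 or with compounds 1 and 3 remains open.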